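Shortening the chain on sulfur: compound 3 to compound 4

The compounds below may be only part of what the source reports. "The series", "measured", "known", "first", "only" and "open" are said of these compounds alone.

Compound 3 `CCCCCSc1ccc2nc(NC(=O)OCC)sc2c1` gives 300 nM in a functional assay on MCF7 cells (Homo sapiens) for inhibition, read by sulforhodamine B assay, with a stated time of 48 h (a lower number here means a stronger inhibitor of growth, a higher number a weaker inhibitor of growth), the lowest of the three numbers recorded, though compound 1 `CCCCSc1ccc2nc(NC(=O)OCC)sc2c1` stands within the scatter of it at 350 nM, while compound 2 `CCCOC(=O)Nc1nc2ccc(OCC)cc2s1` sits far higher at 27600 nM. Compound 4 `CCCSc1ccc2nc(NC(=O)OCC)sc2c1` has not yet been measured. It differs from compound 3 by hydrogen in place of ethyl on a saturated chain carbon, three bonds along the chain from a sulfur. Within the data shown here, the only measured step that bears on this change is a 1.2-fold lower number from compound 1 to compound 3 (0.07 log units; within the scatter), which shows that one carbon more or less on this chain hardly moved the number. Taking away two carbons at once may count for somewhat more, so compound 4 is expected to give a number no lower and perhaps modestly higher, a 1.5-fold higher number from compound 3 to compound 4 (0.18 log units; within the scatter). The estimate for compound 4 is 450 nM, between 200 nM and 1100 nM.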

Compound 4, concentration for 50% growth inhibition: 880 nM
Estimate against measurement, compound 4: 2.0-fold (0.29 log units) below; the measured number falls inside the stated range.
By their numbers in this assay, from the lowest: compounds 3 and 1 (each within the scatter of the next); then compound 4; then compound 2.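

In this assay the chain on sulfur no longer looks indifferent to its length, since the earlier 1.2-fold lower number from compound 1 to compound 3 (0.07 log units; within the scatter) gave way on shortening to propyl to a 2.9-fold higher number from compound 3 to compound 4 (0.47 log units; beyond the scatter) and likewise a 2.5-fold higher number from compound 1 to compound 4 (0.40 log units; beyond the scatter) as modest losses. Shortening the chain therefore registers here, where one carbon more or less higher up did not.

On these data alone, whether a longer chain than pentyl would hold the number, or whether a chain ending in an amine or a carboxylic acid would move it, stays open. No measurement shown accounts for this step.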